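The compounds below may be only part of what the source reports. "The series", "measured", "known", "first", "only" and "open" are said of these compounds alone.

Measured compounds in a functional assay on ECa-109 cells (Homo sapiens) for inhibition, read by MTT assay, with a stated time of 72 h; on this read-out higher numbers stand for weaker inhibition and lower numbers for stronger inhibition:
- compound 1 `Fc1ccc(Cn2cc(CSC(=S)N3CCNCC3)nn2)cc1`: > 128000 nM (a limit of this assay, not a number)
- compound 2 `O=C(OCc1ccccc1)N1CCN(C(=S)SCc2cn(Cc3ccc(F)cc3)nn2)CC1`: 32000 nM
- compound 3 `O=C(OCc1ccccc1)N1CCN(C(=S)SCc2cn(Cc3ccccc3F)nn2)CC1`: 27000 nM

Compound 1 stands at the limit of this assay. That limit, (the limit of > 128000 nM in this assay, at which 1 of the 3 values shown sits), is all that is known for compound 1, so its place among the three cannot be fixed more closely. The step of an at least 4.0-fold lower number from compound 1 to compound 2 (0.60 log units; beyond the scatter) shows that the benzyloxycarbonyl compound 2 falls clearly off that limit, and a 1.2-fold lower number from compound 2 to compound 3 (0.07 log units; within the scatter) shows that moving from 4-fluorophenyl to 2-fluorophenyl leaves compound 3 within the scatter of compound 2.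

Compound 4 `S=C(SCc1cn(Cc2ccccc2Cl)nn1)N1CCNCC1` is compound 1 with 2-chlorophenyl in place of 4-fluorophenyl on a saturated chain carbon bound to an aromatic nitrogen. Among the measured compounds shown here, the only measured step that bears on this change, a 1.2-fold lower number from compound 2 to compound 3 (0.07 log units; within the scatter), concerns a halogen moved on the phenyl ring and lies within the scatter. For the measured compounds named here, compound 4 keeps the unsubstituted amine nitrogen of compound 1, and no measured step covers chlorine in place of fluorine. The expected step that the limit leaves unreadable from compound 1 to compound 4 is therefore none beyond the scatter, with compound 4 likely also ending at the limit. Compound 4 is estimated at 150000 nM, between 50000 nM and 500000 nM.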

Compound 4, half-maximal inhibitory concentration: > 128000 nM
Compound 4: a limit, no number (the forecaster's own chance of this, stated with the estimate: 60%); the middle value is on the limit's open side.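

Compound 1 and compound 4 both end at a limit in this assay, so no new step can be read between them: the limit of > 128000 nM in this assay, at which 2 of the 4 values shown sit.

The compounds shown leave open whether 2-chlorophenyl in place of 4-fluorophenyl alters inhibition at all, as neither compound has a readable number.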